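The source may hold more compounds than are shown below. What is called first, only, known or untested is meant among the compounds shown, and "the series" means these compounds.

For the measured compounds named here, in a functional assay on HepG2 cells (Homo sapiens) for antiproliferative activity, read by sulforhodamine B assay, with a stated time of 72 h (on this read-out higher numbers stand for weaker inhibition and lower numbers for stronger inhibition), compound 1 `O=C(Cn1nc(-c2ccccc2)c2ccccc2c1=O)Nc1ccccc1` gives 13400 nM, the highest number of the three measured so far. Compound 2 `O=C(Cn1nc(-c2ccccc2)c2ccccc2c1=O)Nc1cccc(Cl)c1`, with chloro in place of hydrogen on an aromatic carbon, gives 3290 nM. Compound 3 `O=C(Cn1nc(-c2ccccc2)c2ccccc2c1=O)Nc1cccc(C(F)(F)F)c1`, with trifluoromethyl in place of that hydrogen, gives 3500 nM. Both steps are modest: a 4.1-fold lower number from compound 1 to compound 2 (0.61 log units; beyond the scatter) and a 3.8-fold lower number from compound 1 to compound 3 (0.58 log units; beyond the scatter). Compound 4 `O=C(Cn1nc(Cc2ccccc2)c2ccccc2c1=O)Nc1ccccc1` changes a different place, with benzyl in place of phenyl on an aromatic carbon, next to the ring nitrogen: benzyl in place of phenyl on an aromatic carbon. Going by the values given here, no measured step touches this group, so the data suggest no direction, and no step beyond the scatter is expected in this assay. The estimated change is a 1.2-fold lower number from compound 1 to compound 4 (0.09 log units; within the scatter). For compound 4 the expected value is 11000 nM, with an estimated range of 4000 nM to 30000 nM.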

Compound 4, half-maximal inhibitory concentration: 66000 nM
Compound 4: the middle estimate sits 6.0-fold (0.78 log units) below what was measured; measured number outside the range, above it.
By their numbers in this assay, from the lowest: compounds 2 and 3 (each within the scatter of the next); then compound 1; then compound 4.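

In this assay there is a 4.9-fold higher number from compound 1 to compound 4 (0.69 log units; beyond the scatter) with benzyl in place of phenyl, so this position does respond to change, and in the opposite direction to the chloro and trifluoromethyl steps made elsewhere on the molecule. Phenyl and benzyl have the same hydrogen-bond donor and acceptor counts, and each holds one six-membered aromatic ring of carbon only, so those counts do not separate them. Nothing available explains this higher number. From the compounds shown here alone, whether a longer chain such as phenylethyl, or an amine, would raise or lower the number here remains open. So does whether chloro or trifluoromethyl would lower the number for compound 4 as well.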